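Fluoro on the benzyl ether, carried onto a second core

This account rests on a few compounds, and the source may have more. Where it says the series, first, only, none or still open, it means among the compounds named here.

Compound 1 `O=[N+]([O-])c1cc(C(F)(F)F)cc([N+](=O)[O-])c1Oc1ccccc1/C=N\OCc1ccccc1` carries an unsubstituted benzyl group on the oxime ether. In a functional assay on A549 cells (Homo sapiens) for antiproliferative activity, read by MTT assay, with a stated time of 48 h (on this read-out lower numbers stand for stronger inhibition and higher numbers for weaker inhibition), compound 1 gives 1470 nM. Compound 2 `O=[N+]([O-])c1cc(C(F)(F)F)cc([N+](=O)[O-])c1Oc1ccccc1/C=N\OCc1ccccc1F` differs from it by fluoro in place of hydrogen on an aromatic carbon, and in this assay compound 2 gives 860 nM; the step is a 1.7-fold lower number from compound 1 to compound 2 (0.23 log units; within the scatter). Compound 3 `O=[N+]([O-])c1cc(C(F)(F)F)cc([N+](=O)[O-])c1Oc1c(Br)cc(Br)cc1/C=N\OCc1ccccc1` has a different core, and the difference between the core of compound 1 and the core of compound 3 is not broken down here. In this assay compound 3 gives 2150 nM, which set against compound 2 is a gap beyond the scatter, while set against compound 1 it lies within it. Compound 4 `O=[N+]([O-])c1cc(C(F)(F)F)cc([N+](=O)[O-])c1Oc1c(Br)cc(Br)cc1/C=N\OCc1ccccc1F` has not yet been measured. It differs from compound 3 by fluoro in place of hydrogen on an aromatic carbon, the same change as from compound 1 to compound 2, at the same place on the benzyl ring. Among the measured compounds shown here, the only guide is the one measured pair, so the expected step from compound 3 to compound 4 is estimated as a 1.7-fold lower number from compound 3 to compound 4 (0.22 log units; within the scatter), resting on a 1.7-fold lower number from compound 1 to compound 2 (0.23 log units; within the scatter), with no second instance to check it against. Compound 4 is therefore expected at about 1300 nM in this assay, with a range of 650 nM to 2600 nM to cover the scatter and the fact that the change is being carried onto a core where it has not been tried.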

Compound 4, half-maximal inhibitory concentration: 1560 nM
Compound 4: middle estimate off by 1.2-fold (0.08 log units), on the low side; the range from low to high includes it.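

In this assay, the change from benzyl to 2-fluorobenzyl on the core of compound 3 gives a 1.4-fold lower number from compound 3 to compound 4 (0.14 log units; within the scatter), and set beside the same change on the core of compound 1 it reads alike: the same change on two cores in this assay, a 1.7-fold lower number (0.23 log units; within the scatter) from compound 1 to compound 2 and a 1.4-fold lower number (0.14 log units; within the scatter) from compound 3 to compound 4, 1.2-fold (0.09 log units) apart, within the scatter of two such steps

On these two cores, then, nothing separates the step on one from the step on the other, and the change can be read as carrying over without a visible difference. Each step on its own lies within the scatter, however, so the pair does not establish that fluoro moves the number at all on either core, and two cores are too few to speak for the series as a whole.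

Open, as far as these compounds go, is whether chloro, methoxy or an amine in the same place on the benzyl ring would give a step that clears the scatter on either core. Also open, from the compounds shown here alone, is how a longer chain in place of the benzyl group on the oxime ether would read in this assay, and whether such a change would then behave alike on both cores.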